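A few compounds are considered here, and "the series" means these few. Any claim that something is new, unique, unknown or untested is made for them only; others in the source may bear on it.

In an ADME assay on microsomes from liver (Mus musculus) for metabolic stability, read by LC-MS, using NADPH, with a stated time of 30 min, tested at 0.1 uM, in the presence of a further agent that is not named here (a lower number here means that less of the compound is left, a higher number that more of the compound is left), compound 1 `Nc1ncc(-c2ccc(C(=O)N3CCC(O)C3)cc2)nc1-c1ccc(C(F)(F)F)cc1` gives > 90%, a limit of the assay and not a number. Compound 2 `Nc1ncc(-c2ccc(C(=O)N3CC[C@@H](O)C3)cc2)nc1-c1ccc(C(F)(F)F)cc1` gives > 90%, also a limit. Compound 3 `Nc1ncc(-c2ccc(C(=O)N3CC[C@H](O)C3)cc2)nc1-c1ccc(C(F)(F)F)cc1` gives > 90%, again a limit, so it stands with the other two at the limit of > 90% in this assay, at which 3 of the 3 values shown sit.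

Compound 4 `Nc1ncc(-c2ccc(C(=O)O)cc2)nc1-c1ccc(C(F)(F)F)cc1` departs from compound 3 by hydroxy in place of 3-hydroxypyrrolidin-1-yl on a carbonyl carbon, turning (3-hydroxypyrrolidin-1-yl)carbonyl into carboxy. Among the compounds with values here, three measured steps touch that group only in its configuration: a step that the two limits leave unreadable from compound 1 to compound 2, a step that the two limits leave unreadable from compound 1 to compound 3 and a step that the two limits leave unreadable from compound 2 to compound 3. None has a readable size, and none removes the group.

With the shared core unchanged and compound 3 at > 90%, a limit, no step beyond the scatter is expected in this assay, in either direction. The estimated step is a step that the limit leaves unreadable from compound 3 to compound 4. For compound 4 the expected value is 92%, within an estimated range of 78% to 100%.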

Compound 4, percent of the compound remaining: > 90%
Compound 4 was reported as a limit (the forecaster's own chance of this, stated with the estimate: 55%); the middle value lies beyond the limit too.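

No step from compound 1, compound 2 or compound 3 to compound 4 can be read, because all four compounds sit at one limit: the limit of > 90% in this assay, at which 4 of the 4 values shown sit.

The compounds shown leave open whether carboxy in place of (3-hydroxypyrrolidin-1-yl)carbonyl, or the configuration of that group, shifts the percent of compound remaining at all.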